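The source may report more compounds than this note shows. Statements on the series, on what has been measured and on what is new or still open speak of the compounds shown alone.

Measured so far in a functional assay on NMC-797 cells (Homo sapiens) for antiproliferative activity, with a stated time of 48 h; on this read-out higher numbers stand for weaker inhibition and lower numbers for stronger inhibition:

Compound 1 `O=C1C=C[C@]2(C[C@@H](c3ccccc3[N+](=O)[O-])O[C@@H](c3ccccc3[N+](=O)[O-])O2)O1` gives 64 nM
Compound 2 `O=C1C=C[C@]2(C[C@@H](c3ccccc3)O[C@@H](c3cccc([N+](=O)[O-])c3)O2)O1` gives 120 nM

Both compounds share the same bicyclic core bearing a nitro-substituted phenyl group, and in this assay compound 2 gives 120 nM while compound 1 gives 64 nM. The gap between these two numbers lies within the usual scatter of repeated measurements, so compound 2 cannot be set apart from compound 1 on this read-out.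

Compound 3 `O=C1C=C[C@]2(C[C@@H](c3ccccc3)O[C@@H](c3ccccc3)O2)O1` has not been measured. It differs from compound 2 in one place only: hydrogen in place of nitro on an aromatic carbon. For the measured compounds named here, no measured pair shows the effect of removing a nitro group from this part of the molecule, so nothing in the data fixes the size or direction of this step. Given that compound 1, which carries two nitro groups, and compound 2, which carries one, sit within the scatter of each other in this assay, the expectation for compound 3 is a step from compound 2 that is modest, a 1.5-fold higher number from compound 2 to compound 3 (0.18 log units; within the scatter), with a slight lean toward weaker inhibition. Compound 3 is therefore expected to give about 180 nM in this assay, within a range from 60 nM to 550 nM.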

Compound 3, half-maximal inhibitory concentration: 900 nM
The estimate for compound 3 lay 5.0-fold (0.70 log units) below the measured number; the whole stated range lies below it.
By their numbers in this assay, from the lowest: compounds 1 and 2 (each within the scatter of the next); then compound 3.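

In this assay, hydrogen in place of nitro on an aromatic carbon gives a 7.5-fold higher number from compound 2 to compound 3 (0.88 log units; beyond the scatter) and this is the only pair shown that differs in one place. The step lies beyond the scatter, so this position, meta to a large group on the six-membered aromatic ring, is not indifferent to what it carries, and the nitro group is tied to the stronger inhibition seen with compound 2. For the compounds shown here, nothing measured here explains why this single exchange moves the number so far.

The compounds shown do not tell whether the nitro group itself is needed at this position, or whether another group, such as an amine, a nitrile, a methoxy group or a carboxylic acid, would hold the number near that of compound 2. Going by these compounds alone, they also leave open whether a nitro group elsewhere on the aromatic rings would count for as much, since no pair isolates such a change.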